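Compound 4 in the fluoro-to-trifluoromethoxy step

The source may report more compounds than this note shows. Statements on the series, on what has been measured and on what is new or still open speak of the compounds shown alone.

Measured so far in an ADME assay on MDBK cells (Bos taurus) for cytotoxicity (on this read-out lower numbers stand for higher toxicity in this test and higher numbers for lower toxicity in this test), each value a limit:
- compound 1 `Fc1cccc(Cn2ccc3nc(-c4ccccc4)nc-3c2)c1`: > 100000 nM
- compound 2 `Fc1ccc(Cn2ccc3nc(-c4ccccc4)nc-3c2)cc1`: > 100000 nM
- compound 3 `N#Cc1cccc(Cn2ccc3nc(-c4ccccc4)nc-3c2)c1`: > 100000 nM

Compound 2 stands at > 100000 nM, which is a limit and not a number. Compound 1 and compound 3 offer no number either, so the series has no readable value in this assay yet.

Compound 4 `FC(F)(F)Oc1ccc(Cn2ccc3nc(-c4ccccc4)nc-3c2)cc1` differs from compound 2 by trifluoromethoxy in place of fluoro on an aromatic carbon.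

Among the measured compounds shown here, three measured steps bear on this change. For the measured compounds named here, the first is a step that the two limits leave unreadable from compound 1 to compound 2. The second is a step that the two limits leave unreadable from compound 1 to compound 3. The third is a step that the two limits leave unreadable from compound 2 to compound 3. None of them has a size that can be carried over to compound 4.

The expectation therefore rests on (the limit of > 100000 nM in this assay, at which 3 of the 3 values shown sit), which holds for compound 1, compound 2 and compound 3 alike. No step beyond the scatter is expected in this assay, and no direction can be drawn from the data, although this is a weak basis. The step expected is a number no higher from compound 2 to compound 4 (the limit leaves the size open).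

The estimate for compound 4 is 100000 nM, with an expected range from 35000 nM to 150000 nM.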

Compound 4, half-maximal cytotoxic concentration: 66000 nM
For compound 4 the middle estimate is 1.5-fold (0.18 log units) above the measured one, and the stated range covers the measured number.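

In this assay, among the compounds shown here, compound 4 gives 66000 nM, the first number that is not a limit, and it comes from a change on an aromatic carbon para to a large group. Trifluoromethoxy in place of fluoro gives an at least 1.5-fold lower number from compound 2 to compound 4 (0.18 log units; that floor lies within the scatter), so a real fall on this read-out is possible but is not established by that floor, and its true size stays open. The steps among compound 1, compound 2 and compound 3 cannot be read, and compound 4 is the only value in the series that is not capped: the limit of > 100000 nM in this assay, at which 3 of the 4 values shown sit.

Open, as far as these compounds go, is whether the oxygen or the fluorines of the trifluoromethoxy group go with the number for compound 4, a question that a methoxy group on the same aromatic carbon would help to settle. Also open, from the compounds shown here alone, is whether an amine, a carboxylic acid or a longer chain at this place would give a number well under that of compound 4 or would return to the limit.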